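This account rests on a few compounds, and the source may have more. Where it says the series, first, only, none or still open, it means among the compounds named here.

Compound 1 `CC1=C/C(=C\C(C)C)C(=O)C(C)(O)C12CC2` stands together with compound 2 `C/C=C1\C=C(C)C2(CC2)C(C)(O)C1=O` in a functional assay on A549 cells (Homo sapiens) for antiproliferative activity (on this read-out lower numbers stand for stronger inhibition and higher numbers for weaker inhibition), where compound 1 gives 110 nM and compound 2 gives 150 nM, the two within the scatter of each other. Compound 3 `CC1=C/C(=C\c2cccs2)C(=O)C(C)(O)C12CC2` differs from compound 1 by thiophen-2-yl in place of isopropyl on a double-bonded chain carbon bound to a double-bonded ring carbon. Within the data shown here, the only step measured at that place, a 1.4-fold higher number from compound 1 to compound 2 (0.13 log units; within the scatter), stayed within the scatter. Compound 3 brings an aromatic ring where compound 1 has none, so that step is a loose guide, and no shift in this assay beyond the scatter is firmly expected. Compound 3 is therefore estimated at 150 nM, between 40 nM and 600 nM, an expected step of a 1.4-fold higher number from compound 1 to compound 3 (0.13 log units; within the scatter).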

Compound 3, half-maximal inhibitory concentration: > 10000 nM
Compound 3: only a limit was reported; the forecaster's own chance of this, stated with the estimate: 5%; at least 66-fold (1.82 log units) between middle value and limit.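

In this assay, the place on a double-bonded chain carbon bound to a double-bonded ring carbon proves far from indifferent to its group: isopropyl and methyl lie within the scatter of each other, yet thiophen-2-yl brings an at least 90-fold higher number from compound 1 to compound 3 (1.95 log units; beyond the scatter) and an at least 66-fold higher number from compound 2 to compound 3 (1.82 log units; beyond the scatter). Both steps rest on a limit for compound 3, not on a number: the limit of > 10000 nM in this assay, at which 1 of the 3 values shown sits.

The compounds shown cannot separate the aromatic ring of thiophen-2-yl from its size. They also leave open whether phenyl, cyclohexyl or a longer chain such as n-butyl would behave like thiophen-2-yl or like isopropyl at this place.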